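The source may report more compounds than this note shows. Statements on the series, on what has been measured and on what is new or still open speak of the compounds shown alone.

Working notes on a small series of aryl ketone alkenes read in a functional assay on DU-145 cells (Homo sapiens) for inhibition, read by trypan blue exclusion, with a stated time of 96 h; on this read-out lower numbers stand for stronger inhibition of growth and higher numbers for weaker inhibition of growth.

Compound 3 `Cc1ccc(S(=O)(=O)/C(=C/c2ccc(N(C)C)cc2)C(=O)c2ccc(Cl)cc2)cc1` carries a (4-methylphenyl)sulfonyl on a double-bonded chain carbon bound to a carbonyl carbon and a double-bonded chain carbon. In this assay compound 3 gives only a limit, > 100000 nM. Compound 1 `Cc1ccc(S/C(=C/c2ccc(N(C)C)cc2)C(=O)c2ccc(Cl)cc2)cc1` differs from compound 3 by one change, ((4-methylphenyl)sulfanyl in place of (4-methylphenyl)sulfonyl on a double-bonded chain carbon bound to a carbonyl carbon and a double-bonded chain carbon). In this assay compound 1 likewise gives only a limit, > 100000 nM. The step that the two limits leave unreadable from compound 3 to compound 1 cannot be sized because the limit of > 100000 nM in this assay, at which 3 of the 3 values shown sit, holds for both ends of that pair.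

Compound 2 `Cc1ccc(S(=O)(=O)/C(=C/c2c(F)c(F)c(F)c(F)c2F)C(=O)c2ccc(Cl)cc2)cc1` keeps the (4-methylphenyl)sulfonyl group of compound 3, but the difference between the two cores is not broken down here. In this assay compound 2 also gives only a limit, > 100000 nM.

Compound 4 `Cc1ccc(S/C(=C/c2c(F)c(F)c(F)c(F)c2F)C(=O)c2ccc(Cl)cc2)cc1` is not yet measured. Against compound 2 it shows the change ((4-methylphenyl)sulfanyl in place of (4-methylphenyl)sulfonyl on a double-bonded chain carbon bound to a carbonyl carbon and a double-bonded chain carbon), the same kind of change as that from compound 3 to compound 1, at a place described in the same words. The measured pair leaves the size of this change unreadable, since the limit of > 100000 nM in this assay, at which 3 of the 3 values shown sit, covers every value shown so far.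

The step from compound 2 to compound 4 is expected to be a number no higher from compound 2 to compound 4 (the limit leaves the size open). This expectation rests on the step that the two limits leave unreadable from compound 3 to compound 1 being unreadable within the same series.

For compound 4 the expected value in this assay is 100000 nM, with a range from 30000 nM to 300000 nM. It is expected that the assay again reports only a limit for compound 4.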

Compound 4, concentration for 50% growth inhibition: 25000 nM
Estimate against measurement, compound 4: 4.0-fold (0.60 log units) above; the whole stated range lies above it.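

In this assay, within the data shown here, (4-methylphenyl)sulfanyl in place of (4-methylphenyl)sulfonyl gives an at least 4.0-fold lower number from compound 2 to compound 4 (0.60 log units; beyond the scatter), the one readable step, and it shows that this change can lower the number on the core of compound 2, although the full size of the step stays open. Carried to the core of compound 1, the same change gives no measured number, and compound 1 gives only a limit, > 100000 nM. The matching step from the core of compound 3 therefore cannot be read, so the data neither confirm nor rule out a transfer between the two cores, and the two steps cannot be compared in size, because nearly all values shown are limits: the limit of > 100000 nM in this assay, at which 3 of the 4 values shown sit.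

The compounds shown leave open how other groups on a double-bonded chain carbon bound to a carbonyl carbon and a double-bonded chain carbon would read, such as (4-methylphenyl)sulfinyl or an amine. They also leave open whether the lower number seen with (4-methylphenyl)sulfanyl would appear on a core carrying a carboxylic acid.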